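Inducible nitric oxide synthase series: methoxy to chloro swap

The source may hold more compounds than are shown below. What is called first, only, known or untested is meant among the compounds shown, and "the series" means these compounds.

Measured compounds:
compound 1 `CCC(=O)N1N=C(c2cc(OC)ccc2N)SC1(C)C`: 73%
compound 2 `COc1ccc(N)c(C2=NN(C(=O)C3CCCC3)C(C)(C)S2)c1`: 65%

In an assay on isolated protein for inhibition of Nitric oxide synthase, inducible (Homo sapiens), read by scintillation counting, with a stated time of 30 min, tested at 50 uM (a higher number here means more inhibition at the concentration tested (going by the name of the read-out), a lower number less inhibition), compound 1 gives 73%; compound 2 gives 65%, and the step of a number 8 percentage points lower from compound 1 to compound 2 (within the scatter) lies within the scatter, so compound 1 stands on a par with compound 2 rather than apart from it. Compound 3 `CCC(=O)N1N=C(c2cc(Cl)ccc2N)SC1(C)C` has not yet been measured. It differs from compound 1 by chloro in place of methoxy on an aromatic carbon. Within the data shown here, no measured step touches this part of the molecule: the only measured step, cyclopentyl in place of ethyl on a carbonyl carbon, concerns the carbonyl side and was small. Among the measured compounds shown here, nothing among the measured compounds indicates a direction for the swap of methoxy for chloro, and the expectation defaults to a step of no more than the scatter. For compound 3 the expected value is 68%, with a range of 50% to 85%. The step of a number 5 percentage points lower from compound 1 to compound 3 (within the scatter) is accordingly estimated to be small.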

Compound 3, a percentage reported as inhibition, at one concentration (the size of the read-out at that concentration, not a potency): 1.07%
Estimate against measurement, compound 3: 66.9 percentage points above; the measured number lies below the stated range.
By their numbers in this assay, from the lowest: compound 3; then compounds 2 and 1 (each within the scatter of the next).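

In this assay, the aromatic carbon para to the amino group turns out to be a sensitive place: chloro in place of methoxy there gives a number 71.9 percentage points lower from compound 1 to compound 3 (beyond the scatter), and activity at the tested concentration nearly disappears. The only other step shown, on the carbonyl side, is much smaller: a number 8 percentage points lower from compound 1 to compound 2 (within the scatter). Nothing on hand bears on why this swap has so large an effect.

The compounds shown leave open whether the loss reflects methoxy leaving or chloro entering, as this single pair cannot separate the two. Also open, going by these compounds, is how an ethoxy, a hydroxy, a fluoro or plain hydrogen on this carbon would read, and whether cyclopentyl on the carbonyl carbon would alter the result with chloro in place.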